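Inverting One Ring Stereocentre in a Potent Lactone

The compounds below may be only part of what the source reports. "The series", "measured", "known", "first", "only" and "open" are said of these compounds alone.

Among the measured compounds shown here, compound 2, drawn as `CCC(C)(C)C(=O)O[C@H]1C[C@H](C)[C@@H](O)[C@@H]2CC[C@H](C)[C@H](CC[C@@H]3C[C@@H](O)CC(=O)O3)C12`, is the stronger of the two compounds measured so far in an assay with 3-hydroxy-3-methylglutaryl-coenzyme A reductase (Rattus norvegicus) as the target; a higher number here means a weaker inhibitor, a lower number a stronger inhibitor: compound 2 gives 48.6 nM, whereas compound 1, drawn as `CCC(C)(C)C(=O)O[C@@H](C[C@@H](C)CO)C1[C@H](O)CC[C@H](C)[C@@H]1CC[C@@H]1C[C@@H](O)CC(=O)O1`, gives 2800 nM, a gap well beyond the usual scatter of repeated measurements. Compound 3, drawn as `CCC(C)(C)C(=O)O[C@H]1C[C@@H](C)[C@@H](O)[C@@H]2CC[C@H](C)[C@H](CC[C@@H]3C[C@@H](O)CC(=O)O3)C12`, differs from compound 2 in only one respect: the two compounds have the same atoms and bonds; at least one stereo element is drawn with a configuration in one of them and without one in the other: 1 of 9 stereo elements differ; a stereocentre at a saturated ring carbon is drawn S in compound 2 and R in compound 3. For the measured compounds named here, no pair of measured compounds differs in a single place, so no directly comparable step exists here. Changing the drawn configuration at one ring carbon of a compound in which every other stereo element is fixed can alter activity considerably, and such a change is more often a loss than a gain, though the size cannot be known from these data. Compound 3 is therefore expected to be somewhat weaker, with the estimated step being a 3.1-fold higher number from compound 2 to compound 3 (0.49 log units; beyond the scatter). The estimate for compound 3 in this assay is 150 nM, within a range from 30 nM to 1500 nM.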

Compound 3, half-maximal inhibitory concentration: 40.8 nM
For compound 3 the middle estimate is 3.7-fold (0.57 log units) above the measured one; measured number inside the range.
By their numbers in this assay, from the lowest: compounds 3 and 2 (each within the scatter of the next); then compound 1.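

Among the compounds shown here, this is the first comparison here that changes only one place, and inverting the saturated ring carbon gives a 1.2-fold lower number from compound 2 to compound 3 (0.08 log units; within the scatter) in this assay. With everything else held constant, the measurements therefore cannot separate the S and R drawings at this carbon, so the activity seen for compound 2 does not depend on the S drawing there. This reading needs some care because of how the two structures are drawn: the fact that one of compounds 2 and 3 is drawn with a defined configuration and the other without, at the place where they differ.

The compounds shown only vary the configuration at this carbon, so they leave open how the assay would respond to a different group there, such as a longer chain or an amine. They also cannot show whether this tolerance of both drawings extends to the other stereocentres of the shared core.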